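The source may hold more compounds than are shown below. What is called first, only, known or untested is meant among the compounds shown, and "the series" means these compounds.

Measured compounds:
compound 1, `Nc1cccc(Cn2cc(-c3ccc4cn[nH]c4c3)ccc2=O)c1`, 287 nM
compound 2, `O=c1ccc(-c2ccc3cn[nH]c3c2)cn1Cc1ccccc1`, 315 nM
compound 3, `NC(=O)c1ccccc1Cn1cc(-c2ccc3cn[nH]c3c2)ccc1=O`, 878 nM

All three were tested in an assay for inhibition of MAP kinase-interacting serine/threonine-protein kinase 1 (Homo sapiens), read by luminescence and ADP-Glo, with a stated time of 2 h; on this read-out higher numbers stand for weaker inhibition and lower numbers for stronger inhibition. Compound 2 stands second highest of the three numbers in this assay: its nearest neighbour is compound 1, which gives 287 nM, a difference within the scatter; furthest from it is compound 3, which gives 878 nM.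

Compound 4 is `NC(=O)c1ccc(Cn2cc(-c3ccc4cn[nH]c4c3)ccc2=O)cc1`. It differs from compound 2 by one change, (carbamoyl in place of hydrogen on an aromatic carbon).

Among the measured compounds shown here, two measured steps bear on this. The step of a 1.1-fold higher number from compound 1 to compound 2 (0.04 log units; within the scatter) shows that removing an amino group from the benzyl ring of the shared core changes little. The step of a 2.8-fold higher number from compound 2 to compound 3 (0.45 log units; beyond the scatter) shows that adding a carbamoyl to the same ring, at another of its positions, gave a modest weakening. For the measured compounds named here, compound 4 carries the same carbamoyl at a different place, so the data give no direct measurement of this exact change; the closest precedent is compound 3, and on that basis a modest rise in number is expected, though it could also stay within the scatter.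

Compound 4 is therefore expected to give about 500 nM in this assay, in a range from 220 nM to 1100 nM. This estimate means an expected step of a 1.6-fold higher number from compound 2 to compound 4 (0.20 log units; within the scatter).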

Compound 4, half-maximal inhibitory concentration: > 2000 nM
Compound 4 ended at the assay's limit; the forecaster's own chance of this, stated with the estimate: 2%; at least 4.0-fold (0.60 log units) between middle value and limit.
By their numbers in this assay, from the lowest: compounds 1 and 2 (each within the scatter of the next); then compound 3. At a limit, above all of these: compound 4.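

In this assay compound 4 reads > 2000 nM, which is a limit of the assay and not a number: the limit of > 2000 nM in this assay, at which 1 of the 4 values shown sits. Even so, the step can be read, and the same change on the same ring costs more para to a large group than at the other place on the ring: there the step is a 2.8-fold higher number from compound 2 to compound 3 (0.45 log units; beyond the scatter), and here it is an at least 6.3-fold higher number from compound 2 to compound 4 (0.80 log units; beyond the scatter). The earlier compounds showed only a modest weakening for carbamoyl and no change beyond the scatter for amino (a 1.1-fold higher number from compound 1 to compound 2 (0.04 log units; within the scatter)), so only compound 4 shows that, among these compounds, where the carbamoyl stands can decide how large the step is.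

What the compounds shown leave open is how far compound 4 lies past the limit, and whether the large step belongs to the carbamoyl itself or to any group para to a large group. An amine, a nitrile, a carboxylic acid or a methyl ester at this place would separate those two readings, and none of them stands among the compounds shown.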